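The compounds below may be only part of what the source reports. "The series", "measured", "known", "first", "only" and "open" are said of these compounds alone.

Measured so far in a functional assay on CWR22R cells (Homo sapiens) for antiproliferative activity, read by CCK-8 assay, with a stated time of 6 days (on this read-out lower numbers stand for stronger inhibition and higher numbers for weaker inhibition), are these compounds:

compound 1 `CC(=O)c1cc(C(=O)N[C@H](C)Cn2ccc(-c3cc(F)c(C#N)c(Cl)c3)n2)n[nH]1` gives 15500 nM
compound 2 `CC(O)c1ccc(C(=O)N[C@@H](C)Cn2ccc(-c3ccc(C#N)c(Cl)c3)n2)cc1` gives 9050 nM
compound 3 `C[C@@H](Cn1ccc(-c2ccc(C#N)c(Cl)c2)n1)NC(=O)c1ccccc1F` gives "not determined" (no result reported)

Going by the values given here, compound 3 has no number to stand on, so its place is open and no step can be measured from it. Among the compounds with values here, the only numbers are those of compound 1 and compound 2, and these two values lie within the usual scatter of each other. Compound 4 `C[C@@H](Cn1ccc(-c2ccc(C#N)c(Cl)c2)n1)Nc1cncnc1` is still to be measured in this assay and differs from compound 3 as follows: pyrimidin-5-yl in place of (2-fluorophenyl)carbonyl on an amine nitrogen. In words, pyrimidin-5-yl stands in place of (2-fluorophenyl)carbonyl on an amine nitrogen. Neither measured compound carries this exact change, so the series offers no direct guide to its effect. With no starting value, no direction can be given for the step itself. The working expectation is that compound 4 will sit at the same level as the two measured values in this series, which are compound 2 at 9050 nM and compound 1 at 15500 nM. The estimated value for compound 4 is 10000 nM, with an expected range from 3000 nM to 30000 nM in the same read-out.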

Compound 4, half-maximal inhibitory concentration: > 30000 nM
Compound 4 gave a limit, no number; the forecaster's own chance of this, stated with the estimate: 20%; at least 3.0-fold (0.47 log units) between middle value and limit.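

In this assay compound 4 gives > 30000 nM, which is a limit and not a number. Going by these compounds alone, compound 3 has no reported number, and no step between compound 3 and compound 4 can be read. The compounds shown leave open what pyrimidin-5-yl in place of (2-fluorophenyl)carbonyl on an amine nitrogen does to this read-out.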